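The compounds below may be only part of what the source reports. "The series", "measured", "known", "first", "only" and "open" are said of these compounds alone.

Measured so far in an ADME assay on HEK-293T cells (Homo sapiens) for inhibition, read by CCK-8 assay, with a stated time of 48 h, tested at 20 uM; a higher number here means more inhibition of growth at the concentration tested, a lower number less inhibition of growth:
- compound 1 `COc1ccc(Cc2nnc(NC(=O)/C(C#N)=C/c3ccccc3OS(=O)(=O)c3ccc(F)cc3)s2)cc1`: 6%
- compound 2 `N#C/C(=C\c1ccccc1OS(=O)(=O)c1ccc(F)cc1)C(=O)Nc1nnc(Cc2ccccc2)s1`: 6%
- compound 3 `N#C/C(=C\c1ccccc1OS(=O)(=O)c1ccccc1[N+](=O)[O-])C(=O)Nc1nnc(Cc2ccc(F)cc2)s1`: 6%

Within the data shown here, compound 3, at 6%, stands level with the other two compounds, and no measured compound separates from the rest in this assay. The next compound to read is compound 4 `N#C/C(=C\c1ccccc1OS(=O)(=O)c1ccc(F)cc1)C(=O)Nc1nnc(Cc2ccc(F)cc2)s1`. Its change from compound 3 is 4-fluorophenyl in place of 2-nitrophenyl on a sulfonyl sulfur.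

Among the measured compounds shown here, no measured step covers this exchange directly. For the measured compounds named here, the only measured step, no change at the digits printed from compound 1 to compound 2 (within the scatter), is hydrogen in place of methoxy on an aromatic carbon, so it bears on the question only indirectly. It does show one structural change with no effect on the read-out. More useful is that compound 1 and compound 2 both carry 4-fluorophenyl on the sulfonyl sulfur, as compound 4 will. Compound 2 gives 6% with that group, and compound 3 gives 6% with 2-nitrophenyl there. Three compounds are a thin basis, but nothing in them points to a shift in either direction.

The expected size of no change at the digits printed from compound 3 to compound 4 (within the scatter) is none beyond the scatter. For compound 4 the estimated value is 6%, with an expected range of 0% to 15%.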

Compound 4, percent growth inhibition at one concentration: "not toxic" (no number reported)
No number was reported for compound 4, and the estimate cannot be compared.
By their numbers in this assay, from the lowest: compounds 1, 2 and 3 (each within the scatter of the next).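

In this assay, among these compounds, compound 4 is recorded only as "not toxic", without a number, so no step from compound 3 to compound 4 can be read. As far as these compounds go, whether 4-fluorophenyl in place of 2-nitrophenyl on the sulfonyl sulfur changes growth inhibition stays open. No evidence shown bears on this result.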